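Notes on a chloro exchange in the amide series

A few compounds are considered here, and "the series" means these few. Any claim that something is new, unique, unknown or untested is made for them only; others in the source may bear on it.

Among the compounds with values here, in a functional assay on PC-3 cells (Homo sapiens) for inhibition, read by MTT assay, with a stated time of 24 h, tested at 100 ug/mL (a higher number here means more inhibition of growth at the concentration tested, a lower number less inhibition of growth), only one number exists so far. Compound 1 (`O=C(CCCCC1CCSS1)Nc1ccccn1`) stands at "not determined" (no result reported) with no result reported. Within the data shown here, compound 2 (`O=C(CCCCC1CCSS1)Nc1ccc(Cl)cn1`) gives 42.3% as the sole measured value. Compound 3 (`O=C(CCCCC(S)CCS)Nc1ccccn1`) likewise stands at "not determined" (no result reported) and so has no place on the scale yet. Compound 4 (`O=C(CCCCC(S)CCS)Nc1ccc(Cl)cn1`) still awaits measurement. The structural change is chloro in place of hydrogen on an aromatic carbon and amounts to chloro in place of hydrogen on an aromatic carbon. Among the measured compounds shown here, no measured pair isolates this exchange, so no size or direction can be carried over, and no step beyond the scatter is expected from it in this assay at present. Compound 2 carries the same chloro group, and its 42.3% is the only anchor available. For compound 4 an inhibition of 45% is estimated, with an expected range from 22% to 68% at the concentration tested.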

Compound 4, percent growth inhibition at one concentration: 32.4%
Estimate against measurement, compound 4: 12.6 percentage points above, and the stated range covers the measured number.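

In this assay the chain group without a ring in compound 4 stands in place of the five-membered non-aromatic ring of compound 2, giving a number 9.9 percentage points lower from compound 2 to compound 4 (within the scatter) and so no separation of the two groups at this saturated chain carbon, four bonds along the chain from a carbonyl carbon. Within the data shown here, this is the first reading at that position, while the chloro exchange itself still cannot be read, with compound 3 at "not determined" (no result reported) and no number to set against compound 4. Nothing on hand explains why the two groups give values within the scatter of each other.

From the compounds shown here alone, what chloro in place of hydrogen does on either chain group remains open, since compound 1 also stands at "not determined" (no result reported) in this assay and offers no comparison. Also open, going by these compounds, is how a methoxy group on that aromatic carbon, or a carboxylic acid or a longer chain in place of the sulfur-bearing group, would read.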